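Shifting the amine around the phenyl ring

A few compounds are considered here, and "the series" means these few. Any claim that something is new, unique, unknown or untested is made for them only; others in the source may bear on it.

Compound 2 `Nc1cccc(CCCCCCC(=O)c2ncc(-c3ccccn3)o2)c1` stands at the higher of the two numbers seen so far in an assay for inhibition of Fatty-acid amide hydrolase 1 (Rattus norvegicus); on this read-out lower numbers stand for stronger inhibition and higher numbers for weaker inhibition: compound 2 gives 30 nM, whereas compound 1 `O=C(CCCCCCc1ccc(Cl)cc1)c1ncc(-c2ccccn2)o1` gives 2.7 nM. Among the compounds with values here, the only measured step, an 11-fold higher number from compound 1 to compound 2 (1.05 log units; beyond the scatter), exchanges one group for another and does not bear on the present change. Compound 3 `Nc1ccc(CCCCCCC(=O)c2ncc(-c3ccccn3)o2)cc1` differs from compound 2 by 4-aminophenyl in place of 3-aminophenyl on a saturated chain carbon, six bonds along the chain from a carbonyl carbon. Within the data shown here, no measured step speaks to this change, so its size cannot be read from the data. Compound 3 is expected to give 25 nM, between 7 nM and 90 nM. The expected step of a 1.2-fold lower number from compound 2 to compound 3 (0.08 log units; within the scatter) is therefore judged unlikely to exceed the scatter.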

Compound 3, inhibition constant: 3 nM
For compound 3 the middle estimate is 8.3-fold (0.92 log units) above the measured one, and the stated range ends above it.
By their numbers in this assay, from the lowest: compounds 1 and 3 (each within the scatter of the next); then compound 2.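

In this assay, the placement of the amine on the phenyl ring proves decisive: 4-aminophenyl in place of 3-aminophenyl gives a 10-fold lower number from compound 2 to compound 3 (1.00 log units; beyond the scatter), although the two groups have the same atoms. Amino in place of chloro on an aromatic carbon gives a 1.1-fold higher number from compound 1 to compound 3 (0.05 log units; within the scatter), so 4-aminophenyl and 4-chlorophenyl cannot be told apart here. Nothing measured explains why the two amine placements differ. The compounds shown leave open how a 4-methoxyphenyl or 4-carboxyphenyl group would compare, and whether a longer chain would preserve the difference between the two amines.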